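The source may report more compounds than this note shows. Statements on the series, on what has been measured and on what is new or still open speak of the compounds shown alone.

Measured in a functional assay on PC-3 cells (Homo sapiens) for inhibition, read by MTT assay, with stated times of 18 h and 4 h; on this read-out lower numbers stand for stronger inhibition and higher numbers for weaker inhibition:
compound 1 `CCCCCCCCCCCCCCCCOP(=O)(O)OCCSC(=S)N1CCN(C)CC1`: 95200 nM
compound 2 `CCCCCCOP(=O)(O)OCCSC(=S)N1CCCC1`: > 100000 nM (a limit)
compound 3 `CCCCCCOP(=O)(O)OCCSC(=S)N1CCCCC1`: > 100000 nM (a limit)

Compound 3 gives > 100000 nM, which is a limit of the assay and not a number. The same holds for most of this small set, as the data show (the limit of > 100000 nM in this assay, at which 2 of the 3 values shown sit).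

The next compound is compound 4 `CCCCCCOP(=O)(O)OCCSC(=S)N1CCN(C)CC1`, and the change is 4-methylpiperazin-1-yl in place of piperidin-1-yl on a thiocarbonyl carbon. Among the compounds with values here, the only measured step between close neighbours is a step that the two limits leave unreadable from compound 2 to compound 3, so it offers no size to carry over. Compound 1 gives 95200 nM and carries the entering 4-methylpiperazin-1-yl group, but on a hexadecyl chain where compound 4 has a hexyl chain. With so little to go on, no clear direction is expected in this assay, and the expected step is a step that the limit leaves unreadable from compound 3 to compound 4. A further limit is the likeliest report. For compound 4 the estimated value is 130000 nM, with an expected range of 60000 nM to 300000 nM.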

Compound 4, half-maximal inhibitory concentration: > 100000 nM
Compound 4 was reported as a limit (the forecaster's own chance of this, stated with the estimate: 75%); the middle value lies beyond the limit too.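

In this assay the 4-methylpiperazin-1-yl group on the thiocarbonyl carbon leaves the hexyl chain compounds without a single number, so all three groups shown at this place on that chain end in a limit: the limit of > 100000 nM in this assay, at which 3 of the 4 values shown sit.
The steps among compound 2, compound 3 and compound 4 cannot be read.
The same 4-methylpiperazin-1-yl group can now be compared on two chains, and the result is an at least 1.0-fold higher number from compound 1 to compound 4 (0.02 log units; that floor lies within the scatter), so no difference between the hexadecyl and hexyl chains is established.

As far as these compounds go, whether a morpholine ring or a dimethylamino group at this place would give a measurable value on the hexyl chain stays open.
So does the size of the true gap between the two chains, and whether it holds for the pyrrolidin-1-yl and piperidin-1-yl groups.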